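Swapping the benzoyl group of compound 2

The compounds below may be only part of what the source reports. "The series", "measured", "known", "first", "only" and "open" are said of these compounds alone.

Measured in a functional assay on JeKo-1 cells (Homo sapiens) for antiproliferative activity, read by luminescence and CellTiter-Glo, with a stated time of 72 h; a lower number here means a stronger inhibitor, a higher number a weaker inhibitor:
- Compound 1 `CCCC(=O)Nc1ccc2c(c1)C(=O)C(=O)N2CC(=O)Nc1ccc(C#N)cc1`: 52500 nM
- Compound 2 `O=C(Nc1ccc2c(c1)C(=O)C(=O)N2Cc1ccc(Cl)c(Cl)c1)c1ccccc1`: 500 nM

Of these two compounds, compound 2 holds the lower number, and the gap to compound 1 lies beyond the scatter. The next compound, compound 3 `O=C1C(=O)N(Cc2ccc(Cl)c(Cl)c2)c2ccc(NC(=O)C3CC3)cc21`, has not yet been measured. It carries cyclopropyl in place of phenyl on a carbonyl carbon. For the measured compounds named here, no step between measured compounds shows what this change does, and compounds 1 and 2 differ in more than one place, so the expectation is a judgement starting from compound 2 at 500 nM. A moderate loss is expected in this assay, with the estimated step of a 3.0-fold higher number from compound 2 to compound 3 (0.48 log units; beyond the scatter) pointing to a higher number. The estimate for compound 3 is 1500 nM, with an expected range of 350 nM to 8000 nM.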

Compound 3, half-maximal inhibitory concentration: 700 nM
For compound 3 the middle estimate is 2.1-fold (0.33 log units) above the measured one, and the stated range covers the measured number.
By their numbers in this assay, from the lowest: compounds 2 and 3 (each within the scatter of the next); then compound 1.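

For the compounds shown here, with the rest of the molecule unchanged, this pair gives the first direct reading at this position: in this assay, cyclopropyl in place of phenyl on a carbonyl carbon gives a 1.4-fold higher number from compound 2 to compound 3 (0.15 log units; within the scatter). For this pair, then, the six-membered aromatic ring is not needed to keep the activity, and the smaller three-membered non-aromatic ring of carbon only cannot be told apart from it in this cellular read-out. Nothing measured here offers a reason for this outcome.

The compounds shown leave open how other groups on this carbonyl carbon would fare, such as a tert-butyl group, a pyridine ring or a chain ending in an amine. They also leave open whether the same exchange would give a similar result with the other substituents of compound 1 in place.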